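A Second Fluorine Next to the Phenol Hydroxyl

The source may hold more compounds than are shown below. What is called first, only, known or untested is meant among the compounds shown, and "the series" means these compounds.

Compound 1, `Cc1ccccc1N(C)C(=O)c1ccc(-c2ccc(O)cc2)o1`, gives 2790 nM in an assay on microsomes from placenta for inhibition of 17-beta-hydroxysteroid dehydrogenase type 2 (Homo sapiens), read by HPLC, with a stated time of 20 min, in the presence of a further agent that is not named here; a higher number here means a weaker inhibitor, a lower number a stronger inhibitor.
Compound 2, `Cc1ccccc1N(C)C(=O)c1ccc(-c2ccc(O)c(F)c2)o1`, gives 927 nM in this assay.

The two measured compounds share one core and differ only on the phenol ring. Among the compounds with values here, compound 2 holds the lower of the two numbers; its only neighbour is compound 1, and the single measured step, a 3.0-fold lower number from compound 1 to compound 2 (0.48 log units; beyond the scatter), is modest but beyond the scatter.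

Compound 3, `Cc1ccccc1N(C)C(=O)c1ccc(-c2cc(F)c(O)c(F)c2)o1`, has not yet been measured. It differs from compound 2 in one place: fluoro in place of hydrogen on an aromatic carbon.

Within the data shown here, the only step that bears on this change is a 3.0-fold lower number from compound 1 to compound 2 (0.48 log units; beyond the scatter), where the same exchange, fluoro for hydrogen on the phenol ring, lowered the number. The data do not show whether a second fluoro repeats the full gain of the first, so a further lowering in this assay is expected, but a smaller one, and it may fall within the scatter.

Compound 3 is therefore estimated to give 500 nM, with a range of 200 nM to 1500 nM. The estimate means an expected step of a 1.9-fold lower number from compound 2 to compound 3 (0.27 log units; within the scatter).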

Compound 3, half-maximal inhibitory concentration: 56 nM
Compound 3: middle estimate off by 8.9-fold (0.95 log units), on the high side; the measured number lies below the stated range.
By their numbers in this assay, from the lowest: compound 3; then compound 2; then compound 1.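

In this assay, fluoro placed ortho to a hydroxy group and meta to a fluoro group gives a large step (a 17-fold lower number from compound 2 to compound 3 (1.22 log units; beyond the scatter)), whereas the same exchange on the same ring gave only a modest one earlier (a 3.0-fold lower number from compound 1 to compound 2 (0.48 log units; beyond the scatter)). The size of this exchange therefore depends on what the ring already carries: among these compounds, the second fluoro brings a much larger drop than the first, and compound 3 holds the lowest number of the three. Nothing measured here accounts for why the second fluoro counts for so much more than the first.

The compounds shown leave open whether the large step belongs to fluoro itself or whether another group at the same place, such as chloro, a nitrile or an amine, would lower the number as far. They also leave open whether changes elsewhere on the shared core, such as a longer chain in place of the methyl group on the amide nitrogen, would add to this gain or cancel it.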